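A chloro group replaced at the assay's limit

The source may report more compounds than this note shows. Statements on the series, on what has been measured and on what is new or still open speak of the compounds shown alone.

Two amides built on the same core start this series: compound 1 `CN(C)c1cccc(NC(=O)CCSc2ccc3c(/C=C/c4ccccn4)n[nH]c3c2)c1` and compound 2 `O=C(CCSc1ccc2c(/C=C/c3ccccn3)n[nH]c2c1)Nc1ccc(Cl)c(C(F)(F)F)c1`. In an ADME assay on BaF3 cells (Mus musculus) for antiproliferative activity, read by CCK-8 assay, with a stated time of 72 h (a higher number here means a weaker inhibitor of growth, a lower number a stronger inhibitor of growth), compound 1 gives > 10000 nM, which is a limit of the assay and not a number. In this assay, compound 2 gives > 10000 nM, again a limit and not a number. Compound 2 therefore has no exact position on the scale, and both measurements share (the limit of > 10000 nM in this assay, at which 2 of the 2 values shown sit).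

Compound 3 `Cc1cn(Cc2ccc(NC(=O)CCSc3ccc4c(/C=C/c5ccccn5)n[nH]c4c3)cc2C(F)(F)F)cn1` keeps the core of compound 2 and differs in one place: (4-methyl-1H-imidazol-1-yl)methyl in place of chloro on an aromatic carbon, ortho to a trifluoromethyl group ((4-methyl-1H-imidazol-1-yl)methyl in place of chloro on an aromatic carbon).

Among the compounds with values here, the only measured step that bears on this change is a step that the two limits leave unreadable from compound 1 to compound 2. It offers neither a size nor a direction, so no shift beyond the usual scatter can be predicted from it. The expectation rests on compound 2, whose > 10000 nM is a limit, and stays close to that limit. The expected change is a number no higher from compound 2 to compound 3 (the limit leaves the size open). Compound 3 is estimated at 10000 nM, with an expected range from 2500 nM to 30000 nM.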

Compound 3, concentration for 50% growth inhibition: 1990 nM
Estimate against measurement, compound 3: 5.0-fold (0.70 log units) above; the measured number lies below the stated range.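

In this assay, putting (4-methyl-1H-imidazol-1-yl)methyl in place of chloro gives an at least 5.0-fold lower number from compound 2 to compound 3 (0.70 log units; beyond the scatter). Within the data shown here, this aromatic carbon, ortho to a trifluoromethyl group, is thus a place where a single change moves the result beyond the scatter, and compound 3 at 1990 nM is the only one of the three compounds with an exact number. The earlier step on the amide nitrogen cannot be read, and the new step gives only a smallest possible size, because compound 1 and compound 2 both sit at the limit of the assay: the limit of > 10000 nM in this assay, at which 2 of the 3 values shown sit.

The entering group brings a five-membered aromatic ring, a methyl on that ring and a linking carbon all at once, so the compounds shown do not tell which of these parts matters, or whether the ring must be there at all. On these data alone, whether an open-chain amine or a carboxylic acid at this same place would give a number lower or higher than that of compound 3 also remains open.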